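The source may report more compounds than this note shows. Statements on the series, on what has been measured and on what is new or still open speak of the compounds shown alone.

Measured compounds:
compound 1 `Cc1cccc(S(=O)(=O)Nc2ccc3oc(-c4ccccc4)nc3c2)c1` gives 69000 nM
compound 2 `C=Cc1ccc(S(=O)(=O)Nc2ccc3oc(-c4ccccc4)nc3c2)cc1` gives 53000 nM
compound 3 `COc1cccc(S(=O)(=O)Nc2ccc3oc(-c4ccccc4)nc3c2)c1` gives 63000 nM

In an ADME assay on HEK293 cells (Homo sapiens) for cytotoxicity, read by resazurin assay, with a stated time of 48 h (on this read-out higher numbers stand for lower toxicity in this test and lower numbers for higher toxicity in this test), compound 3 gives 63000 nM, the second highest of the three numbers, and its gaps to compound 1 and to compound 2 both lie within the scatter. Compound 4 `CS(=O)(=O)Nc1ccc2oc(-c3ccccc3)nc2c1` differs from it by methyl in place of 3-methoxyphenyl on a sulfonyl sulfur. Going by the values given here, the steps that bear on this are the other two changes on the same sulfonyl sulfur: a 1.2-fold higher number from compound 2 to compound 3 (0.08 log units; within the scatter) and a 1.1-fold lower number from compound 1 to compound 3 (0.04 log units; within the scatter), both exchanges of one aromatic group for another, neither beyond the scatter. Among the compounds with values here, no measured step removes the aromatic ring altogether, so the three values only show that this position has so far moved this assay little. Compound 4 is therefore expected to show a 1.3-fold higher number from compound 3 to compound 4 (0.10 log units; within the scatter), and its estimated value is 80000 nM, with a range from 40000 nM to 160000 nM.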

Compound 4, half-maximal cytotoxic concentration: > 100000 nM
Compound 4: no number, only a limit; the forecaster's own chance of this, stated with the estimate: 25%; at least 1.2-fold (0.09 log units) between middle value and limit.
By their numbers in this assay, from the lowest: compounds 2, 3 and 1 (each within the scatter of the next). At a limit, above all of these: compound 4.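

In this assay compound 4 gives > 100000 nM, which is a limit and not a number. Going by these compounds alone, this is the first change that removes the aromatic ring from the sulfonyl sulfur, and the steps read an at least 1.5-fold higher number from compound 3 to compound 4 (0.20 log units; that floor lies within the scatter), an at least 1.8-fold higher number from compound 2 to compound 4 (0.27 log units; that floor lies within the scatter) and an at least 1.4-fold higher number from compound 1 to compound 4 (0.16 log units; that floor lies within the scatter), each a floor only. From the compounds shown here alone, the aromatic ring is thus not needed for the numbers to stay this high, but how far the true value of compound 4 lies from the others remains unknown.

What the compounds shown leave open is how a longer alkyl chain, an amine or a carboxylic acid on this sulfonyl sulfur would read in this assay.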